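Swapping Isopropyl for Hydroxyethyl on a Largely Inactive Core

The compounds below may be only part of what the source reports. "The series", "measured", "known", "first", "only" and "open" are said of these compounds alone.

Of the compounds shown here, three sharing one core have been tested in a functional assay on A549 cells (Homo sapiens) for cytotoxicity, read by MTT assay, with a stated time of 72 h; on this read-out higher numbers stand for weaker inhibition and lower numbers for stronger inhibition. Compound 1 `Cc1oc2ncnc(Nc3cccc(Cl)c3)c2c1C(=O)NC(C)C` gives only a limit of the assay in this assay, > 1000000 nM, and not a measured number. Compound 3 `CCOC(=O)c1c(C)oc2ncnc(Nc3cccc(Br)c3)c12` likewise reaches only a limit, > 1000000 nM. Among the compounds with values here, compound 2 `Cc1cccc(Nc2ncnc3oc(C)c(C(=O)O)c23)c1` is the one member with a number in this assay, 100000 nM. Most of what is known is therefore a boundary: the limit of > 1000000 nM in this assay, at which 2 of the 3 values shown sit.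

Compound 4 `Cc1oc2ncnc(Nc3cccc(Cl)c3)c2c1C(=O)NCCO` is built from compound 1 by a single change, (2-hydroxyethyl in place of isopropyl on an amide-type nitrogen). Within the data shown here, no two measured compounds differ in one place, so no measured step guides this swap. Compound 1 stands at a limit, and compound 4 is expected to stay there too, with a step of a number no higher from compound 1 to compound 4 (the limit leaves the size open) that is no more than the usual scatter. The estimate for compound 4 in this assay is 1000000 nM, within a range from 200000 nM to 5000000 nM, most likely reported as a limit again.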

Compound 4, half-maximal inhibitory concentration: > 1000000 nM
Compound 4: only a limit was reported; the forecaster's own chance of this, stated with the estimate: 75%; the middle value lies on the limit itself.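

Within the data shown here, compound 4, like compound 1, gives only a limit in this assay, so no step between compound 1 and compound 4 can be read. Whether 2-hydroxyethyl and isopropyl differ in effect on this core stays open, because most results shown stop at the same boundary: the limit of > 1000000 nM in this assay, at which 3 of the 4 values shown sit.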